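This account rests on a few compounds, and the source may have more. Where it says the series, first, only, none or still open, it means among the compounds named here.

Series notes. For the measured compounds named here, compound 1 `CN(C)CCCCCn1c2c(c3ccccc31)C(=O)c1c[n+]([O-])c3ccccc3c1C2=O` carries a 5-(dimethylamino)pentyl chain on the shared core; in a functional assay on A-375 cells (Homo sapiens) for cytotoxicity, read by MTT assay, with a stated time of 72 h (on this read-out higher numbers stand for weaker inhibition and lower numbers for stronger inhibition), compound 1 gives 560 nM, the highest of the three numbers so far. Going by the values given here, compound 2 `O=C1c2c[n+]([O-])c3ccccc3c2C(=O)c2c1c1ccccc1n2Cc1cn([C@@H]2C[C@H](O)[C@@H](CO)O2)nn1` gives 20 nM and compound 3 `CC1(C)OC[C@@H](Cn2cc(Cn3c4c(c5ccccc53)C(=O)c3c[n+]([O-])c5ccccc5c3C4=O)nn2)O1` gives 450 nM; the one single-point step among them, a 23-fold higher number from compound 2 to compound 3 (1.35 log units; beyond the scatter), concerns the substituent on the aromatic nitrogen of the triazole arm, not the chain. Compound 1 and compound 3 sit within the scatter of each other.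

Compound 4 `CN1CCN(CCCn2c3c(c4ccccc42)C(=O)c2c[n+]([O-])c4ccccc4c2C3=O)CC1` differs from compound 1 by 4-methylpiperazin-1-yl in place of 2-(dimethylamino)ethyl on a saturated chain carbon, three bonds along the chain from an aromatic nitrogen. Among the compounds with values here, no measured step touches the amine end of the chain, so no shift beyond the scatter is expected. Compound 4 is therefore estimated near 500 nM, between 150 nM and 1700 nM. The step this implies, a 1.1-fold lower number from compound 1 to compound 4 (0.05 log units; within the scatter), is expected to stay within the scatter.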

Compound 4, half-maximal inhibitory concentration: 470 nM
Beside the measured number, compound 4's estimate is 1.1-fold (0.03 log units) above it; the measured number falls inside the stated range.
By their numbers in this assay, from the lowest: compound 2; then compounds 3, 4 and 1 (each within the scatter of the next).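

In this assay the change at the amine end of the chain gives a 1.2-fold lower number from compound 1 to compound 4 (0.08 log units; within the scatter) and so stays within the scatter. At this position, then, 4-methylpiperazin-1-yl with its six-membered ring and 2-(dimethylamino)ethyl with no ring cannot be told apart, which the earlier step on the triazole arm could not show. No evidence on hand bears on this result.

The compounds shown leave open whether a morpholine or a carboxylic acid at the chain end would move the number. They also leave open whether a shorter or longer chain carrying 4-methylpiperazin-1-yl would do so.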